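The source may report more compounds than this note shows. Statements on the series, on what has been measured and on what is new or still open speak of the compounds shown alone.

Measured compounds in a functional assay on isolated protein for inhibition of Glucose-dependent insulinotropic receptor (Rattus norvegicus), read by HTRF and cAMP accumulation; a higher number here means a larger maximal response, a lower number a smaller maximal response:

compound 1, `Cc1nc(S(C)(=O)=O)ccc1Oc1ncnc(OC2CCN(C(=O)O[C@@H](C)CF)CC2)c1F`, gives 84%
compound 2, `Cc1nc(S(C)(=O)=O)ccc1Oc1ncnc(OC2CCN(C(=O)OC3(C(F)(F)F)CCC3)CC2)c1F`, gives 82%
compound 3, `Cc1nc(S(C)(=O)=O)ccc1Oc1ncnc(OC2CCN(C(=O)SC3CC3)CC2)c1F`, gives 80%

Compound 1 holds the largest of the three numbers in this assay, but its two steps to the other compounds, a number 2 percentage points lower from compound 1 to compound 2 (within the scatter) and a number 4 percentage points lower from compound 1 to compound 3 (within the scatter), are both within the scatter, so the three compounds are not separated.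

Compound 4, `CCc1cnc(C(=O)N2CCC(Oc3ncnc(Oc4ccc(S(C)(=O)=O)nc4C)c3F)CC2)nc1`, is not yet measured. Against compound 1 the change is a group of 8 heavy atoms (6 carbon, 2 nitrogen; one six-membered aromatic ring with 2 hetero atoms) in place of a group of 5 heavy atoms (3 carbon, 1 oxygen, 1 fluorine; no ring), on a carbonyl carbon.

Within the data shown here, the steps that bear on this are those that also alter the group on the carbonyl carbon: a number 2 percentage points lower from compound 1 to compound 2 (within the scatter), a number 4 percentage points lower from compound 1 to compound 3 (within the scatter) and a number 2 percentage points lower from compound 2 to compound 3 (within the scatter). Each is within the scatter, although none of them brings in an aromatic ring or nitrogen at this position, so they only partly cover the change to compound 4. On this basis no step beyond the scatter is expected in this assay for compound 4, with the estimated step being a number 4 percentage points lower from compound 1 to compound 4 (within the scatter). Compound 4 is therefore estimated at 80%, with a range from 66% to 92%.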

Compound 4, largest response reached (reported as efficacy), in percent of the reference or control that the assay uses: 80%
Compound 4: middle estimate and measured number agree at the digits printed; low and high end bracket the measured number.
By their numbers in this assay, from the lowest: compounds 3, 4, 2 and 1 (each within the scatter of the next).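

In this assay, 5-ethylpyrimidin-2-yl brings an aromatic ring and ring nitrogen onto the carbonyl carbon whose other neighbour is the amide-type nitrogen in a ring, yet the maximal response stays within the scatter of all three earlier compounds: a number 4 percentage points lower from compound 1 to compound 4 (within the scatter), a number 2 percentage points lower from compound 2 to compound 4 (within the scatter) and no change at the digits printed from compound 3 to compound 4 (within the scatter). Among these four compounds, the group on this carbonyl carbon can therefore be attached through an aromatic ring carbon, as well as through oxygen or sulfur, without a step beyond the scatter. No measurement is available to explain this flat result.

Still open, from the compounds shown here alone, is whether a group such as a primary amine or a carboxylic acid in place of the ethyl on the pyrimidine would keep the response. The four compounds also share the rest of the structure, so they say nothing about changes made elsewhere on the core.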